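A few compounds are considered here, and "the series" means these few. Any claim that something is new, unique, unknown or untested is made for them only; others in the source may bear on it.

Measured so far:
compound 1 `CCc1ccccc1-n1nc(C)c2c1NC(=O)[C@H](C)S[C@@H]2c1ccc(Oc2ccccc2)cc1`: 1100 nM
compound 2 `Cc1ccccc1-n1nc(C)c2c1NC(=O)[C@H](C)S[C@@H]2c1ccc(-c2ccco2)cc1`: 3600 nM
compound 3 `Cc1nn(-c2ccccc2Br)c2c1C(c1ccc(Oc3ccccc3)cc1)SC(C)C(=O)N2`: 1800 nM

In an assay on isolated protein for agonist activity at Bile acid receptor (Homo sapiens), read by AlphaScreen, with a stated time of 30 min (on this read-out lower numbers stand for an effect already at smaller amounts and higher numbers for an effect only at larger amounts of compound), compound 2 gives the highest of the three numbers. Compound 3 sits within the scatter of it, so no order can be read there, while compound 1 sits beyond the scatter at a lower number. Compound 4 `Cc1ccccc1-n1nc(C)c2c1NC(=O)[C@H](C)S[C@@H]2c1ccc(Oc2ccccc2C(=O)O)cc1` has not yet been measured. It differs from compound 2 in one place: 2-carboxyphenoxy in place of furan-2-yl on an aromatic carbon. Within the data shown here, no step between measured compounds isolates this change, so the expectation rests on the spread of the three numbers. Compound 4 is expected to give 700 nM, within a range of 250 nM to 2500 nM. The estimated step of a 5.1-fold lower number from compound 2 to compound 4 (0.71 log units; beyond the scatter) is expected to run toward lower numbers and to reach just beyond the scatter.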

Compound 4, half-maximal effective concentration: "not active" (no number reported)
Nothing numeric was reported for compound 4, so the estimate cannot be set against anything.
By their numbers in this assay, from the lowest: compounds 1, 3 and 2 (each within the scatter of the next, the first and the last beyond it).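

Among these compounds, compound 4 was reported as not active in this assay, without a number, so no step from compound 2 can be read. No evidence bears on this result. The compounds shown leave open which part of the 2-carboxyphenoxy group goes with this outcome.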